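Estimating Compound 4 from Three Measured Analogues

The source may report more compounds than this note shows. Statements on the series, on what has been measured and on what is new or still open speak of the compounds shown alone.

Three compounds sharing one core were tested in a functional assay on A549 cells (Homo sapiens) for cytotoxicity, read by MTT assay, with a stated time of 72 h; on this read-out higher numbers stand for weaker inhibition and lower numbers for stronger inhibition. Compound 1 `O=C(Nc1ccc(-n2ncc3c(C(F)(F)F)cccc32)cc1)Nc1ccc(Cl)c(C(F)(F)F)c1` gives 3000 nM, compound 2 `O=C(Nc1ccc(-n2ncc3c(Br)cccc32)cc1)Nc1ccc(Cl)c(C(F)(F)F)c1` gives 2300 nM, and compound 3 `CNc1cccc2c1cnn2-c1ccc(NC(=O)Nc2ccc(Cl)c(C(F)(F)F)c2)cc1` gives 4900 nM. Compound 2 sits at the lower end of this set: a 1.3-fold lower number from compound 1 to compound 2 (0.12 log units; within the scatter) lies within the scatter, a 1.6-fold higher number from compound 1 to compound 3 (0.21 log units; within the scatter) also stays within it, whereas a 2.1-fold higher number from compound 2 to compound 3 (0.33 log units; beyond the scatter) lies beyond it. Compound 4 `O=C(Nc1ccc(-n2ncc3cnccc32)cc1)Nc1ccc(Cl)c(C(F)(F)F)c1` differs from compound 2 by a group of 9 heavy atoms (6 carbon, 3 nitrogen; one five-membered aromatic ring with 2 hetero atoms, one six-membered aromatic ring with 1 hetero atom) in place of a group of 10 heavy atoms (7 carbon, 2 nitrogen, 1 bromine; one five-membered aromatic ring with 2 hetero atoms, one six-membered aromatic ring of carbon only), on an aromatic carbon. All three measured steps at this aromatic carbon are modest, so this change is expected to shift the number only slightly, if at all, beyond the scatter, perhaps toward a higher number as seen in a 2.1-fold higher number from compound 2 to compound 3 (0.33 log units; beyond the scatter). Compound 4 is therefore expected to give 4000 nM, within 1500 nM to 10000 nM. For compound 4 this estimate means a 1.7-fold higher number from compound 2 to compound 4 (0.24 log units; within the scatter).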

Compound 4, half-maximal inhibitory concentration: 3400 nM
The estimate for compound 4 lay 1.2-fold (0.07 log units) above the measured number; measured number inside the range.
By their numbers in this assay, from the lowest: compounds 2, 1, 4 and 3 (each within the scatter of the next, the first and the last beyond it).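

Replacing the whole 4-bromo-1H-indazol-1-yl group with one whose six-membered aromatic ring carries a hetero atom gives a 1.5-fold higher number from compound 2 to compound 4 (0.17 log units; within the scatter) in this assay. The earlier steps shown here changed only the group on an aromatic carbon, whereas this one alters the ring itself and removes the bromo group, yet the number stays within the scatter. Nothing available bears on why this change has so small an effect.

The compounds shown leave open how compound 4 would respond to an added amine or carboxylic acid on that ring. They also leave open whether a morpholine group there would change the number beyond the scatter.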